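This account rests on a few compounds, and the source may have more. Where it says the series, first, only, none or still open, it means among the compounds named here.

Measured so far:
Compound 1 `c1ccc2nc(N3CC(Oc4nccnc4N4CCCCC4)C3)ccc2c1`: in a physicochemical assay for solubility, in phosphate buffer, at pH 7.4 (on this read-out higher numbers stand for higher solubility and lower numbers for lower solubility), compound 1 gives < 1000 nM, which is a limit of the assay.
Compound 2 `c1ccc2ncc(-c3nccnc3OC3CN(c4ccc5ccccc5n4)C3)cc2c1`: in this assay compound 2 gives < 1000 nM, likewise a limit of the assay.

For the measured compounds named here, compound 1 thus stands at a limit in this assay, and the one further value shown is a limit as well, so that (the limit of < 1000 nM in this assay, at which 2 of the 2 values shown sit). Going by the values given here, the single measured step, a step that the two limits leave unreadable from compound 1 to compound 2, replaces piperidin-1-yl with quinolin-3-yl on an aromatic carbon, and its size cannot be read from two limits. Compound 3 `c1ccc2nc(N3CC(Oc4nccnc4-c4ccc5scnc5c4)C3)ccc2c1` differs from compound 1 by 1,3-benzothiazol-5-yl in place of piperidin-1-yl on an aromatic carbon. Among the compounds with values here, that step is the only one bearing on the change to compound 3, since both exchange the piperidin-1-yl for an aromatic bicycle at the same place, but it gives no size to carry over. Compound 3 is therefore expected to sit at or near the same limit, with an expected step that the limit leaves unreadable from compound 1 to compound 3 that cannot be called beyond the scatter. Compound 3 is estimated at 400 nM, within 50 nM to 1500 nM.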

Compound 3, solubility: < 1000 nM
Compound 3 was reported as a limit; the forecaster's own chance of this, stated with the estimate: 85%; the middle value does not contradict the limit.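

No new step can be read among compound 1, compound 2 and compound 3: the limit of < 1000 nM in this assay, at which 3 of the 3 values shown sit. The compounds shown leave open how far their true values lie from that limit, and whether 1,3-benzothiazol-5-yl in place of piperidin-1-yl or quinolin-3-yl changes the read-out at all.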